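The source may hold more compounds than are shown below. What is called first, only, known or untested is meant among the compounds shown, and "the series" means these compounds.

Two compounds share a single core and differ only in the group attached to it. Compound 1 `CCC1=C(O)c2c(oc(-c3cccc(C(F)(F)F)c3)cc2=O)C(CC)(CC)C1=O` carries a trifluoromethyl on its aromatic ring, and in a functional assay on KB cells (Homo sapiens) for antiproliferative activity, read by sulforhodamine B assay, with a stated time of 3 days (on this read-out lower numbers stand for an effect already at smaller amounts and higher numbers for an effect only at larger amounts of compound), compound 1 gives 35.7 uM. Compound 2 `CCC1=C(O)c2c(oc(-c3cccc(OC)c3)cc2=O)C(CC)(CC)C1=O` carries a methoxy there instead, and in this assay compound 2 gives 13.3 uM. Among the compounds with values here, the swap of methoxy for trifluoromethyl produced a 2.7-fold lower number from compound 1 to compound 2 (0.43 log units; beyond the scatter), so compound 2 stands at the lower of the two numbers measured so far, with compound 1 its only neighbour.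

Compound 3 `CCC1=C(O)c2c(oc(-c3ccc(OC)c(Cl)c3)cc2=O)C(CC)(CC)C1=O` is the next step: 3-chloro-4-methoxyphenyl in place of 3-methoxyphenyl on an aromatic carbon. Within the data shown here, the one measured step, from compound 1 to compound 2, concerned the exchange of one group for another and says nothing about adding a chlorine or about a methoxy in a different position; it bears on this change only loosely, as a sign that the ring substituent can shift the number by a modest amount. Among the measured compounds shown here, with no direct precedent, compound 3 is expected to land close to compound 2, giving a 1.1-fold lower number from compound 2 to compound 3 (0.04 log units; within the scatter). The estimate for compound 3 in this assay is therefore 12 uM, within a range from 4 uM to 35 uM.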

Compound 3, concentration for half-maximal effect: 24.9 uM
Estimate against measurement, compound 3: 2.1-fold (0.32 log units) below, and the stated range covers the measured number.
By their numbers in this assay, from the lowest: compounds 2, 3 and 1 (each within the scatter of the next, the first and the last beyond it).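

In this assay, replacing 3-methoxyphenyl with 3-chloro-4-methoxyphenyl gives a 1.9-fold higher number from compound 2 to compound 3 (0.27 log units; within the scatter), so the two compounds cannot be told apart in this measurement. The earlier step exchanged one group for another, whereas this one shows that the aromatic ring on the shared core can carry an added chlorine, with the methoxy numbered differently, and still give a number within the scatter of compound 2. Nothing available on these compounds explains this result.

From the compounds shown here alone, two things differ at once between these groups, the chlorine and the place of the methoxy, so their separate contributions remain unknown, and they could even be pulling in opposite directions; 3-chlorophenyl and 4-methoxyphenyl would be the groups that pull them apart. Also open, going by these compounds, is how this ring would respond to groups of a quite different kind, such as an amine or a carboxylic acid, since every group seen so far is a trifluoromethyl, a methoxy or a chlorine.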